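Trimethoxyphenyl pyrazolyl chalcones: adding one more methoxy group

The source may hold more compounds than are shown below. What is called first, only, known or untested is meant among the compounds shown, and "the series" means these compounds.

Measured compounds:
compound 1 `COc1ccc(-c2cc(/C=C/C(=O)c3ccc(N)cc3)[nH]n2)cc1` — 45%
compound 2 `COc1ccc(C(=O)/C=C/c2cc(-c3cc(OC)c(OC)c(OC)c3)n[nH]2)cc1OC` — 11%
compound 3 `COc1ccc(-c2cc(/C=C/C(=O)c3ccc(N)cc3)[nH]n2)cc1OC` — 34%

In a functional assay on SR cells (Homo sapiens) for cytotoxicity, read by sulforhodamine B assay, with a stated time of 48 h, tested at 1 uM (a lower number here means a stronger effect, a higher number a weaker effect of the compound at the concentration tested), compound 1 gives 45%. Compound 3 carries the change methoxy in place of hydrogen on an aromatic carbon and gives 34%, a step of a number 11 percentage points lower from compound 1 to compound 3 (beyond the scatter). Compound 2 gives 11%, the lowest of the three numbers; the difference between the core of compound 2 and the core of compound 1 is not broken down here.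

Compound 4 `COc1cc(C(=O)/C=C/c2cc(-c3cc(OC)c(OC)c(OC)c3)n[nH]2)cc(OC)c1OC` has not yet been measured. It differs from compound 2 by methoxy in place of hydrogen on an aromatic carbon. Within the data shown here, this is the same kind of change as the one from compound 1 to compound 3, though here the entering group also stands meta to a methoxy group. Among the measured compounds shown here, with only one measured instance, the expectation rests on the step from compound 1 to compound 3 and on the low starting point of compound 2, which is already the strongest in this assay. The step from compound 2 to compound 4 is expected to be a number 5 percentage points lower from compound 2 to compound 4 (within the scatter). Compound 4 is estimated at 6% in this assay, between -5% and 20%.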

Compound 4, a percentage reported as activity, at one concentration (the size of the read-out at that concentration, not a potency): 22%
Estimate against measurement, compound 4: 16 percentage points below, and the stated range ends below it.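

On the core of compound 2, methoxy in place of hydrogen on an aromatic carbon weakens the effect in this assay, with a number 11 percentage points higher from compound 2 to compound 4 (beyond the scatter). The same kind of change strengthened the effect on the core of compound 1, so in this series the direction of the step does not carry over from one core to the other: the same change on two cores in this assay, a number 11 percentage points lower (beyond the scatter) from compound 1 to compound 3 and a number 11 percentage points higher (beyond the scatter) from compound 2 to compound 4, 22 percentage points apart, beyond the scatter of two such steps. This rests on just two pairs of compounds, and it shows neither why the two cores respond differently nor how a further core would respond.

The compounds shown leave open whether a different group in the same place, such as a hydroxy group or a chlorine atom, would also move the read-out in opposite directions on the two cores. They also leave open whether the opposite steps would persist at concentrations other than the single one tested.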